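The source may hold more compounds than are shown below. What is called first, only, known or untested is meant among the compounds shown, and "the series" means these compounds.

Compound 1 `Cc1noc(C)c1-c1nn(Cc2ccc(C(=O)NC3CC3)cc2)c(=O)c2ccccc12`: > 100000 nM
Compound 2 `Cc1noc(C)c1-c1nn(Cc2ccc(C(=O)NC3CC(C)(C)N([O])C(C)(C)C3)cc2)c(=O)c2ccccc12`: 84300 nM

Going by the values given here, in a functional assay on A549 cells (Homo sapiens) for antiproliferative activity, read by MTT assay, with a stated time of 72 h (a higher number here means a weaker inhibitor, a lower number a stronger inhibitor), compound 2 gives 84300 nM, the only true number so far. Compound 1 reads > 100000 nM, which is a limit of the assay and not a number. Compound 3 `Cc1noc(C)c1-c1nn(Cc2ccc(C(=O)NC3CCCC3)cc2)c(=O)c2ccccc12` changes compound 2 as follows: a group of 5 heavy atoms (5 carbon; one five-membered non-aromatic ring of carbon only) in place of a group of 11 heavy atoms (9 carbon, 1 nitrogen, 1 oxygen; one six-membered non-aromatic ring with 1 hetero atom), on an amide-type nitrogen. Among the compounds with values here, its carbon-only ring resembles that of compound 1, and the one measured step, an at least 1.1-fold lower number from compound 1 to compound 2 (0.07 log units; that floor lies within the scatter), gives no ground for expecting a large change. The expected step is a 1.2-fold higher number from compound 2 to compound 3 (0.07 log units; within the scatter), which is none beyond the scatter. For compound 3 the estimate is 100000 nM, with an expected range from 40000 nM to 250000 nM.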

Compound 3, half-maximal inhibitory concentration: > 100000 nM
Compound 3: only a limit was reported; the forecaster's own chance of this, stated with the estimate: 60%; the middle value sits exactly at the limit.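

Compound 3 and compound 1 both give only a limit in this assay, so neither carbon-only ring yields a true number on this amide-type nitrogen: the limit of > 100000 nM in this assay, at which 2 of the 3 values shown sit.

Swapping the six-membered ring for cyclopentyl gives an at least 1.1-fold higher number from compound 2 to compound 3 (0.07 log units; that floor lies within the scatter), so the data do not show that this change matters. The step between the two limits cannot be read.

As far as these compounds go, it remains open whether any group on this nitrogen can bring a true number well under the limit. A phenyl ring or a carboxylic acid-bearing chain there would read how, the compounds shown cannot say.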